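A Thienopyrimidinone Urea: From Dimethylphenyl to Chloroethoxyphenyl

The source may hold more compounds than are shown below. What is called first, only, known or untested is meant among the compounds shown, and "the series" means these compounds.

Of the compounds shown here, two have been measured in an assay on isolated protein for binding affinity to melanin-concentrating hormone receptor 1 (Homo sapiens); on this read-out higher numbers stand for weaker inhibition and lower numbers for stronger inhibition. Compound 1 `CN(C(=O)N1CC[C@H](n2cnc3cc(-c4ccc(Cl)cc4)sc3c2=O)C1)[C@H]1CCN(CC2CC2)C1` gives 3 nM in this assay. Compound 2 `Cc1ccc(-c2cc3ncn([C@H]4CCN(C(=O)N(C)[C@H]5CCN(C)C5)C4)c(=O)c3s2)c(C)c1` gives 49 nM in this assay, the higher of the two numbers, set apart from compound 1 by a gap that is well beyond the scatter of repeat measurements. Since compound 1 and compound 2 differ in more than one place, their two values alone cannot be assigned to any single change.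

Compound 3 `CCOc1ccc(-c2cc3ncn([C@H]4CCN(C(=O)N(C)[C@H]5CCN(C)C5)C4)c(=O)c3s2)c(Cl)c1` is the next compound to be measured in this assay. It differs from compound 2 in one place: 2-chloro-4-ethoxyphenyl in place of 2,4-dimethylphenyl on an aromatic carbon. Among the compounds with values here, no step between two measured compounds isolates the effect of such an exchange on the aryl ring, so the size of this step is uncertain. The spread between compound 2 and compound 1 shows that this assay is sensitive to changes around the core, and a modest shift toward a lower number is expected for the step of a 2.7-fold lower number from compound 2 to compound 3 (0.43 log units; beyond the scatter). Compound 3 is therefore estimated to give 18 nM in this assay, with a plausible range from 5 nM to 65 nM.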

Compound 3, inhibition constant: 26 nM
Beside the measured number, compound 3's estimate is 1.4-fold (0.16 log units) below it; low and high end bracket the measured number.
By their numbers in this assay, from the lowest: compound 1; then compounds 3 and 2 (each within the scatter of the next).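

In this assay, the exchange of 2,4-dimethylphenyl for 2-chloro-4-ethoxyphenyl on the aromatic carbon next to the ring sulfur gives a 1.9-fold lower number from compound 2 to compound 3 (0.28 log units; within the scatter), and this is the only step shown that isolates this position. The entering group has 10 heavy atoms against 8 and brings one hydrogen-bond acceptor where the leaving group has none, yet this read-out does not separate the two aryl groups, so the position holds the larger, oxygen-bearing group with no change beyond the scatter. No measured evidence shown here bears on this result. Within the data shown here, whether the chlorine and the ethoxy each leave the number unchanged or instead offset one another stays open, since the single step exchanges the chloro-ethoxy pair against the two methyl groups at once. Also open, from the compounds shown here alone, is what a 2-chloro-4-methylphenyl, or an aryl ring carrying an amine, a carboxylic acid or an alkoxy chain longer than ethoxy, would give on this shared core and urea.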